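The source may hold more compounds than are shown below. What is called first, only, known or untested is meant among the compounds shown, and "the series" means these compounds.

Measured compounds:
compound 1 `CC(C)(C)c1ccc(C(=O)NCc2ccc(N)cc2Cl)cc1`: 46 nM
compound 2 `CC(C)(C)c1ccc(C(=O)NCc2ccc(S(N)(=O)=O)cc2)cc1`: 1400 nM
compound 3 `Cc1ccc(C(=O)NCc2ccc(C(=O)O)cc2)cc1C`: 320 nM

Compound 2 stands at the highest number of the three. In an assay on HeLa cells with Bile acid receptor (Homo sapiens) as the target, read by a luciferase reporter, with a stated time of 24 h (a higher number here means that more compound is needed for the effect, a lower number that less compound is needed), compound 2 gives 1400 nM. The nearest of the others is compound 3, which in this assay gives 320 nM, a gap beyond the scatter; furthest is compound 1, which gives 46 nM, also beyond the scatter.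

Compound 4 `CN(C)C(=O)c1ccc(CNC(=O)c2ccc(C(C)(C)C)cc2)cc1` differs from compound 2 in one place: dimethylcarbamoyl in place of sulfamoyl on an aromatic carbon.

Going by the values given here, no pair of measured compounds shares this change, so its size cannot be read from a measured step. Among the compounds with values here, what is known is only that compound 2 carries the highest number and that the two other groups tried at that position both give lower numbers. A step downward of moderate size, beyond the scatter, is therefore expected, but with wide uncertainty: the expected step is a 2.8-fold lower number from compound 2 to compound 4 (0.45 log units; beyond the scatter). For compound 4 the estimate in this assay is 500 nM, within a range from 120 nM to 2000 nM.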

Compound 4, half-maximal effective concentration: 170 nM
For compound 4 the middle estimate is 2.9-fold (0.47 log units) above the measured one; low and high end bracket the measured number.
By their numbers in this assay, from the lowest: compound 1; then compounds 4 and 3 (each within the scatter of the next); then compound 2.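

In this assay, the position on an aromatic carbon para to a large group now has a measured step: dimethylcarbamoyl in place of sulfamoyl gives an 8.2-fold lower number from compound 2 to compound 4 (0.92 log units; beyond the scatter), which shows that this position responds to the group it carries. Sulfamoyl has 1 hydrogen-bond donor and dimethylcarbamoyl has 0 hydrogen-bond donors, but this one pair also changes sulfur to carbon and adds the methyl groups, so it cannot assign the step to any single feature. No measurement on hand accounts for the step.

On these data alone, it remains open whether plain carbamoyl, without the two methyl groups, would give a number close to that of compound 4. Dimethylsulfamoyl, which keeps the sulfur and adds the two methyl groups, would test the other half of the change.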